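Cytotoxicity notes on the shared core: compound 3 to compound 4

The compounds below may be only part of what the source reports. "The series", "measured", "known", "first", "only" and "open" are said of these compounds alone.

Three compounds of the series carry a reading in an ADME assay on Huh-7 cells (Homo sapiens) for cytotoxicity; a higher number here means that more compound is tolerated, a lower number that less compound is tolerated. Compound 1 `CN1CCN(CCCNCc2cn(-c3ccc(C(F)(F)F)cc3)nc2-c2ccc(OC(F)(F)F)cc2)CC1` gives 2300 nM. Compound 2 `Cc1ccccc1-c1nn(-c2cccc(Cl)c2)cc1CNCCN1CCN(C)CC1` gives 16000 nM. For compound 3 `Cc1ccccc1CNc1nn(-c2ccc(F)cc2F)cc1CNCCN1CCN(C)CC1` the assay returns only a limit, > 20000 nM, and no number. On the numbers shown compound 3 therefore stands at the tolerated end, (the limit of > 20000 nM in this assay, at which 1 of the 3 values shown sits), while compound 1 and compound 2 have finite values, with compound 1 the lower of the two.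

Compound 4 `CN1CCN(CCNCc2cn(-c3ccc(F)cc3F)nc2C2CCCCC2)CC1` has not yet been run in this assay. Compared with compound 3 it differs in one place: cyclohexyl in place of (2-methylbenzyl)amino on an aromatic carbon. The (2-methylbenzyl)amino group leaves and a cyclohexyl enters, so one six-membered aromatic ring of carbon only gives way to one six-membered non-aromatic ring of carbon only, and the single hydrogen-bond donor and acceptor of the leaving group are gone. Going by the values given here, no measured pair isolates this change, so the step can only be guessed. For compound 4 a modest shift toward lower tolerance is expected, an at least 1.4-fold lower number from compound 3 to compound 4 (0.15 log units; that floor lies within the scatter), roughly the size of the scatter rather than clearly beyond it. Compound 4 is accordingly estimated at 14000 nM, within 5000 nM to 30000 nM, with a fair chance that the assay again reports only a limit.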

Compound 4, half-maximal cytotoxic concentration: > 20000 nM
Compound 4 was reported as a limit; the forecaster's own chance of this, stated with the estimate: 35%; middle value at least 1.4-fold (0.15 log units) from the limit.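

In this assay compound 3 and compound 4 both return only a limit, so the change from (2-methylbenzyl)amino to cyclohexyl gives no readable step between them: the limit of > 20000 nM in this assay, at which 2 of the 4 values shown sit.

The compounds shown leave open where the true tolerated concentrations of compound 3 and compound 4 lie, and whether this change shifts tolerance at all.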